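Aryl swap at the triazole: chloro to trifluoromethyl

A few compounds are considered here, and "the series" means these few. Any claim that something is new, unique, unknown or untested is made for them only; others in the source may bear on it.

Compound 1 `C/C(=C\CC/C(C)=C/CC[C@@H]1[C@@]2(C)CCC(=O)C(C)(C)[C@H]2CC[C@@]1(C)O)CC/C=C(\C)C(=O)OCc1cn(-c2ccccc2[N+](=O)[O-])nn1` gives > 150000 nM in a functional assay on A549 cells (Homo sapiens) for antiproliferative activity, read by MTT assay, with a stated time of 48 h (a lower number here means a stronger inhibitor, a higher number a weaker inhibitor), a limit of the assay.
Compound 2 `COc1ccc(-n2cc(COC(=O)/C(C)=C/CC/C(C)=C/CC/C(C)=C/CC[C@@H]3[C@@]4(C)CCC(=O)C(C)(C)[C@H]4CC[C@@]3(C)O)nn2)cc1` gives > 150000 nM in this assay, likewise a limit.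
Going by the values given here, compound 3 `C/C(=C\CC/C(C)=C/CC[C@@H]1[C@@]2(C)CCC(=O)C(C)(C)[C@H]2CC[C@@]1(C)O)CC/C=C(\C)C(=O)OCc1cn(-c2cccc(Cl)c2)nn1` gives 147000 nM in this assay, the only number in the set.

Among the compounds with values here, compound 3 thus stands as the sole measured value; the steps of an at least 1.0-fold lower number from compound 1 to compound 3 (0.00 log units; that floor lies within the scatter) and an at least 1.0-fold lower number from compound 2 to compound 3 (0.00 log units; that floor lies within the scatter) are floors within the scatter, and a step that the two limits leave unreadable from compound 1 to compound 2 cannot be read. Compound 4 `C/C(=C\CC/C(C)=C/CC[C@@H]1[C@@]2(C)CCC(=O)C(C)(C)[C@H]2CC[C@@]1(C)O)CC/C=C(\C)C(=O)OCc1cn(-c2cccc(C(F)(F)F)c2)nn1` differs from compound 3 by trifluoromethyl in place of chloro on an aromatic carbon. Within the data shown here, no measured step covers trifluoromethyl; the aryl swaps seen so far gave no readable shift, with two values sitting at the limit of > 150000 nM in this assay, at which 2 of the 3 values shown sit. The expected step of a 1.0-fold higher number from compound 3 to compound 4 (0.01 log units; within the scatter) is therefore none beyond the scatter. Compound 4 is estimated at 150000 nM, within 80000 nM to 300000 nM, with a fair chance that only a limit is reported.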

Compound 4, half-maximal inhibitory concentration: > 150000 nM
Compound 4 gave a limit, no number (the forecaster's own chance of this, stated with the estimate: 50%); the middle value sits exactly at the limit.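

In this assay, trifluoromethyl in place of chloro on an aromatic carbon gives an at least 1.0-fold higher number from compound 3 to compound 4 (0.00 log units; that floor lies within the scatter). The steps to compound 4 from compound 1 and from compound 2 join two limits and cannot be read. A fourth aryl group therefore brings no readable shift, and the limit now dominates the series: the limit of > 150000 nM in this assay, at which 3 of the 4 values shown sit.

Open, going by these compounds, is whether an amine or a carboxylic acid on this aromatic ring would give a number clear of that limit. Going by these compounds alone, also open is whether the aryl groups have any readable order, with compound 3 the only one carrying a number.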